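The source may hold more compounds than are shown below. What is called first, only, known or untested is meant among the compounds shown, and "the series" means these compounds.

Of the compounds shown here, three have been measured in a functional assay on A2780 cells (Homo sapiens) for antiproliferative activity; a higher number here means a weaker inhibitor of growth, a lower number a stronger inhibitor of growth.
Compound 1 `Cl[C@H]1CCO[C@@H](c2ccccc2)C1` gives > 100000 nM, a limit of the assay and not a number.
Compound 2 `O=[N+]([O-])c1ccc([C@H]2C[C@@H](Cl)CCO2)cc1` gives > 100000 nM, again a limit of the assay.
Compound 3 `CC(C)C[C@H]1C[C@@H](Cl)C[C@@H](c2ccccc2)O1` gives 17000 nM.

Compound 2 arises from compound 1 by nitro in place of hydrogen on an aromatic carbon, and the step that the two limits leave unreadable from compound 1 to compound 2, due to the limit of > 100000 nM in this assay, at which 2 of the 3 values shown sit. Compound 4 `CC(C)C[C@H]1C[C@@H](Cl)C[C@@H](c2ccc([N+](=O)[O-])cc2)O1` has not yet been measured; it arises from compound 3 by nitro in place of hydrogen on an aromatic carbon. This is the same kind of change, not the same one: in compound 1 the place is para to a group of 7 heavy atoms, in compound 3 it is para to a large group. The difference between the two cores is not broken down here. The expected step is a 1.1-fold lower number from compound 3 to compound 4 (0.05 log units; within the scatter), which rests on compound 3 alone with 17000 nM, as the earlier step has no readable size. Compound 4 is expected near 15000 nM, estimated between 4000 nM and 60000 nM.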

Compound 4, concentration for 50% growth inhibition: 21000 nM
Compound 4: middle estimate off by 1.4-fold (0.15 log units), on the low side; low and high end bracket the measured number.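

In this assay nitro in place of hydrogen on an aromatic carbon gives a 1.2-fold higher number from compound 3 to compound 4 (0.09 log units; within the scatter) and so, on this core, the two values cannot be told apart. This is a single readable step, and it does not show whether the change behaves the same way on another core. The matching step on the core of compound 1 cannot be read, due to a limit at both of its ends: the limit of > 100000 nM in this assay, at which 2 of the 4 values shown sit.

The compounds shown leave open what an amine or a carboxylic acid in that same place would do to the number. They also leave open whether nitro would give a similar step on a further core whose values are numbers and not limits.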